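The source may hold more compounds than are shown below. What is called first, only, known or untested is meant among the compounds shown, and "the series" means these compounds.

Measured compounds:
- compound 1 `CC(=O)N(Cc1ccccc1)c1cc(C)cc(C)c1` — 276 nM
- compound 2 `CC(=O)N(Cc1ccc(OC(C)C)cc1)c1cc(C)cc(C)c1` — 823 nM
- compound 3 `CC(=O)N(Cc1ccc(OCc2ccccc2)cc1)c1cc(C)cc(C)c1` — 377 nM

All three share one core and differ only on the benzyl ring. In an assay on membranes from HEK293 cells for displacement of a labelled ligand from Translocator protein (Homo sapiens), read by scintillation counting, with a stated time of 90 min (a higher number here means a weaker inhibitor, a lower number a stronger inhibitor), compound 1 gives the lowest of the three numbers. The step of a 1.4-fold higher number from compound 1 to compound 3 (0.14 log units; within the scatter) lies within the scatter, so compound 1 and compound 3 cannot be ordered; the step of a 3.0-fold higher number from compound 1 to compound 2 (0.47 log units; beyond the scatter) is modest but beyond the scatter, as is a 2.2-fold lower number from compound 2 to compound 3 (0.34 log units; beyond the scatter).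

Compound 4 `CCN(CC)C(=O)CN(Cc1ccccc1)c1cc(C)cc(C)c1` is not yet measured. Against compound 1 the change is (diethylcarbamoyl)methyl in place of acetyl on a nitrogen on an aromatic ring. Within the data shown here, none of the measured steps touches this position: every step recorded so far concerns a substituent on the benzyl ring, while the acetyl group is held constant throughout. Among the measured compounds shown here, no measured pair therefore bears on the step from compound 1 to compound 4, and the size of the change in this assay cannot be read from the series.

With nothing to anchor it, the expectation for compound 4 is set near compound 1, with a wide range on either side. The estimate for compound 4 is 200 nM, with a range from 40 nM to 1000 nM; the expected step is a 1.4-fold lower number from compound 1 to compound 4 (0.14 log units; within the scatter).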

Compound 4, inhibition constant: 1010 nM
Compound 4: middle estimate off by 5.1-fold (0.70 log units), on the low side; measured number above the stated range.
By their numbers in this assay, from the lowest: compounds 1 and 3 (each within the scatter of the next); then compounds 2 and 4 (each within the scatter of the next).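

Among these compounds, the nitrogen position, held as acetyl through compounds 1 to 3, now proves open to change in this assay: (diethylcarbamoyl)methyl in place of acetyl gives a 3.7-fold higher number from compound 1 to compound 4 (0.56 log units; beyond the scatter), a modest step but one beyond the scatter, and the first reading of this position. The entering group carries 8 heavy atoms against 3 in the group it replaces, while the counts of hydrogen-bond donors and acceptors, the count of double bonds outside aromatic rings and the net charge stay the same, so the step goes with added chain atoms and not with any difference in those counts. No measurement bears on the cause of this step, and it remains a description only.

A single replacement cannot show which part of the entering group goes with the step, and a propionyl group, a dimethylcarbamoylmethyl group or a chain ending in an amine or a carboxylic acid on this nitrogen would separate chain length from the terminal amide. Also open, going by these compounds, is whether the isopropoxy and benzyloxy steps on the benzyl ring hold when (diethylcarbamoyl)methyl replaces acetyl.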